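Benzamide series: swapping the ring-nitrogen substituent

The source may report more compounds than this note shows. Statements on the series, on what has been measured and on what is new or still open speak of the compounds shown alone.

Measured compounds:
compound 1, `Nc1ccccc1NC(=O)c1ccc(CSC(=S)N2CCN(Cc3ccccn3)CC2)cc1`, 20.7%
compound 2, `Nc1ccccc1NC(=O)c1ccc(CSC(=S)N2CCc3ccccc32)cc1`, 25.7%

Two compounds have been run in a functional assay on A-375 cells (Homo sapiens) for antiproliferative activity, read by CCK-8 assay, with a stated time of 72 h, tested at 2 uM; a higher number here means a stronger effect of the compound at the concentration tested, a lower number a weaker effect. Compound 1 gives 20.7%, and compound 2 gives 25.7%. On these two numbers compound 1 stands lowest, but its nearest neighbour, compound 2, lies within the usual scatter of it, so no order between the two can be read off. Both values are modest at the concentration tested.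

Compound 3, `Nc1ccccc1NC(=O)c1ccc(CSC(=S)N2CCN(c3ccc(F)cc3)CC2)cc1`, has not been measured. Relative to compound 1 it carries a 4-fluorophenyl in place of the (pyridin-2-yl)methyl on an amine nitrogen in a ring, the six-membered non-aromatic ring with 2 nitrogen: 4-fluorophenyl in place of (pyridin-2-yl)methyl on an amine nitrogen in a ring. Among the measured compounds shown here, no step between two measured compounds that differ in one place is available, so nothing in the numbers points to a direction for this change. The expectation is therefore a step from compound 1 to compound 3 of a number 3.3 percentage points higher from compound 1 to compound 3 (within the scatter) in this assay, none beyond the scatter. Compound 3 is estimated at 24%, with a range from 8% to 42%.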

Compound 3, a percentage reported as inhibition, at one concentration (the size of the read-out at that concentration, not a potency): 20.9%
For compound 3 the middle estimate is 3.1 percentage points above the measured one; the range from low to high includes it.
By their numbers in this assay, from the lowest: compounds 1, 3 and 2 (each within the scatter of the next).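

Placing 4-fluorophenyl in place of (pyridin-2-yl)methyl on the amine nitrogen in the ring gives, in this assay, a number 0.2 percentage points higher from compound 1 to compound 3 (within the scatter), the first step that can be read at this position. The exchange swaps the aromatic ring with a hetero atom for one of carbon only and loses the hydrogen-bond acceptor counted in (pyridin-2-yl)methyl, yet this read-out at the single concentration tested does not separate the two compounds, so at this position the acceptor and the fluorine are not distinguished here. No measured data on the compounds bear on why the read-out stays flat across this exchange.

Going by these compounds, whether any substituent on this nitrogen can move the read-out beyond the scatter remains open, since a carboxylic acid, a dimethylaminoethyl chain or an acetyl group on the same nitrogen would test groups quite unlike the two aromatic ones compared here. The values also leave potency open, as a read-out at one concentration gives the size of the effect there and no concentration-response relationship.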